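Swapping methoxy for nitro on a weak compound

The source may report more compounds than this note shows. Statements on the series, on what has been measured and on what is new or still open speak of the compounds shown alone.

compound 1 `CCCn1c(=O)n(C2OC(COP(=O)(O)O)[C@@H](O)[C@H]2O)c2nc(N)nc(O)c21` gives 15 uM
compound 2 `COc1ccc(Cn2c(=O)n(C3OC(CO)[C@@H](O)[C@H]3O)c3nc(N)nc(O)c32)cc1` gives 135 uM
compound 3 `C=CCn1c(=O)n(CCCC)c2nc(N)nc(O)c21` gives 2 uM

All three values come from a functional assay (B cells) with Mus musculus as the target; on this read-out higher numbers stand for an effect only at larger amounts of compound and lower numbers for an effect already at smaller amounts. Compound 2 has the highest number of the three, so it needs the largest amount to produce its effect. Compound 1 and compound 3 both sit lower, by steps beyond the scatter. Among the compounds with values here, these three compounds differ in several places at once, so no measured pair shows what a single swap does.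

The next compound, compound 4 `Nc1nc(O)c2c(n1)n(C1OC(CO)[C@@H](O)[C@H]1O)c(=O)n2Cc1ccc([N+](=O)[O-])cc1`, changes compound 2 in one place: nitro in place of methoxy on an aromatic carbon. Put simply, 4-methoxybenzyl becomes 4-nitrobenzyl. Within the data shown here, with no measured step to guide the size, only a small change is expected, probably none beyond the scatter, and its direction is uncertain. The estimate therefore stays close to compound 2 at 135 uM. The estimated change is a 1.2-fold lower number from compound 2 to compound 4 (0.09 log units; within the scatter). For compound 4 the expected value is 110 uM, within an estimated range of 35 uM to 350 uM.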

Compound 4, concentration for half-maximal effect: 40 uM
Beside the measured number, compound 4's estimate is 2.8-fold (0.44 log units) above it, within the range that was stated.
By their numbers in this assay, from the lowest: compound 3; then compound 1; then compound 4; then compound 2.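

In this assay, within the data shown here, nitro in place of methoxy gives a 3.4-fold lower number from compound 2 to compound 4 (0.53 log units; beyond the scatter) and this is the first step here that isolates a single change. It shows that the group on this aromatic carbon, para to a large group, affects the amount of compound needed, and that replacing 4-methoxybenzyl with 4-nitrobenzyl moves the number down by a modest step. Nothing measured here explains why the swap has this effect.

This single pair gives one direction at one place, so it cannot show whether an amine, a chlorine atom or a carboxylic acid on the same carbon would lower the number further or raise it. It also leaves open whether the same swap would produce a similar step in a compound that differs elsewhere on the shared core.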